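The source may hold more compounds than are shown below. What is called first, only, known or untested is meant among the compounds shown, and "the series" means these compounds.

Measured in a functional assay on MDA-MB-231 cells (Homo sapiens) for cytotoxicity, read by ELISA, with a stated time of 2 days; a lower number here means a stronger inhibitor, a higher number a weaker inhibitor:
- compound 1 `Oc1cccc(-c2cc(-c3ccccc3)nc(-c3cccs3)c2)c1`: 17700 nM
- compound 2 `Oc1cccc(-c2cc(-c3ccccc3)nc(-c3ccco3)c2)c1`: 20800 nM

In this assay compound 2 gives 20800 nM, which is within the scatter of compound 1, so the two stand level. The next compound, compound 3 `Oc1cccc(-c2cc(-c3ccccc3)nc(-c3ccccn3)c2)c1`, changes the same position of the shared core: pyridin-2-yl in place of furan-2-yl on an aromatic carbon. Here pyridin-2-yl takes the place of furan-2-yl, next to the ring nitrogen.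

Going by the values given here, only one measured step bears on this: a 1.2-fold higher number from compound 1 to compound 2 (0.07 log units; within the scatter). That exchange of thiophen-2-yl for furan-2-yl made no visible difference, but neither compound carries a six-membered aromatic ring at this position, so the evidence is thin. With no sign that this position moves the number, no clear rise or fall is expected. The expected change is a 1.2-fold lower number from compound 2 to compound 3 (0.06 log units; within the scatter), with no step beyond the scatter anticipated. For compound 3 the estimated value is 18000 nM, with an expected range of 7000 nM to 45000 nM.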

Compound 3, half-maximal inhibitory concentration: 18700 nM
Compound 3: the middle estimate sits 1.0-fold (0.02 log units) below what was measured; measured number inside the range.
By their numbers in this assay, from the lowest: compounds 1, 3 and 2 (each within the scatter of the next).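

Going by these compounds alone, a six-membered aromatic ring now stands at this position for the first time, and in this assay pyridin-2-yl in place of furan-2-yl gives a 1.1-fold lower number from compound 2 to compound 3 (0.05 log units; within the scatter) and pyridin-2-yl in place of thiophen-2-yl gives a 1.1-fold higher number from compound 1 to compound 3 (0.02 log units; within the scatter) with both steps inside the scatter. Across these three aromatic rings, neither the ring size nor the hetero atom, whether oxygen, sulfur or nitrogen, has visibly moved the number. No measurement at hand says why these groups stand level.

From the compounds shown here alone, all three groups are aromatic rings, so it remains open whether an amine, a carboxylic acid or a longer chain at this position would shift the number. Changes to the 3-hydroxyphenyl group and the phenyl group, which stay the same in all three compounds, also remain open.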